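The source may report more compounds than this note shows. Statements on the series, on what has been measured and on what is new or still open speak of the compounds shown alone.

Measured in a functional assay on HT-1080 cells (Homo sapiens) for antiproliferative activity, read by MTT assay, with a stated time of 72 h; on this read-out higher numbers stand for weaker inhibition and lower numbers for stronger inhibition:
- compound 1 `COc1ccc(-c2ssc(=S)c2-c2cc(OC)c(OC)c(OC)c2)cc1N`: 834 nM
- compound 2 `COc1ccc(-c2c(-c3cc(OC)c(OC)c(OC)c3)ss/c2=N/O)cc1`: > 100000 nM (a limit)
- compound 3 `COc1ccc(-c2c(-c3cc(OC)c(OC)c(OC)c3)ss/c2=N/O)cc1[N+](=O)[O-]`: 3030 nM

For the measured compounds named here, only two of these values are actual numbers. Compound 3 holds the higher one at 3030 nM, while compound 1 gives the lower at 834 nM. Compound 2 stands at the limit of > 100000 nM.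

The next change leads to compound 4 `COc1ccc(-c2c(-c3cc(OC)c(OC)c(OC)c3)ss/c2=N/O)cc1N`, with amino in place of nitro on an aromatic carbon.

Going by the values given here, one measured step concerns this same carbon: an at least 33-fold lower number from compound 2 to compound 3 (1.51 log units; beyond the scatter). From the compounds shown here alone, it is large, but one end is a limit, so its true size remains open, and it shows nitro against hydrogen, not against amino. Among the compounds with values here, no measured step compares amino with nitro directly. Within the data shown here, compound 1 is the only amino compound with a number, and its core differs from that of compound 3. The result for compound 1 at 834 nM still suggests that amino is compatible with a sub-micromolar result.

A moderate move toward a lower number is therefore expected, though with wide uncertainty. The expected change is a 3.0-fold lower number from compound 3 to compound 4 (0.48 log units; beyond the scatter). For compound 4 the estimated value is 1000 nM, with an expected range of 150 nM to 8000 nM.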

Compound 4, half-maximal inhibitory concentration: 2910 nM
Compound 4: the middle estimate sits 2.9-fold (0.46 log units) below what was measured; the range from low to high includes it.
By their numbers in this assay, from the lowest: compound 1; then compounds 4 and 3 (each within the scatter of the next). At a limit, above all of these: compound 2.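

Nitro and amino read alike at this aromatic carbon, ortho to a methoxy group, in this assay: a 1.0-fold lower number from compound 3 to compound 4 (0.02 log units; within the scatter). The earlier compounds shown here gave only the contrast of nitro with hydrogen, and amino now shows a contrast of the same kind: an at least 34-fold lower number from compound 2 to compound 4 (1.53 log units; beyond the scatter). Compound 2 carries hydrogen at this carbon and stands at a limit, so the true size of this step and of an at least 33-fold lower number from compound 2 to compound 3 (1.51 log units; beyond the scatter) remains open: the limit of > 100000 nM in this assay, at which 1 of the 4 values shown sits.

Within the shared core, then, a measurable number goes with either nitro or amino at this carbon, and the exchange of one for the other does not separate the two compounds, although the groups differ in their heavy atoms and hydrogen-bond donors. Still open is whether a hydroxyl, a methyl or an acetamide at this carbon would also read like nitro and amino, and whether the reading for amino depends on the core, since compound 1 gives 834 nM and compound 4 gives 2910 nM with no hydrogen counterpart shown for the core of compound 1.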